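A few compounds are considered here, and "the series" means these few. Any claim that something is new, unique, unknown or untested is made for them only; others in the source may bear on it.

Measured so far in a functional assay on cells (Mus musculus) for cytotoxicity, read by MTT assay, with a stated time of 24 h, tested at 10 uM; on this read-out higher numbers stand for a stronger effect at the one concentration tested and lower numbers for a weaker effect:

Compound 1 `COc1cc(/C=N/Nc2nc3ccccc3s2)cc(OC)c1O` — 55%
Compound 2 `COc1cc(/C=N/N(C)c2nc3ccccc3s2)cc(OC)c1O` — 110%
Compound 3 `COc1cc(/C=N/Nc2nc3ccccc3s2)ccc1O` — 61%

Compound 3 stands second highest of the three numbers. Its nearest neighbour is compound 1; the step of a number 6 percentage points higher from compound 1 to compound 3 (within the scatter) lies within the scatter, so the two cannot be told apart. The furthest is compound 2, whose value in this assay is well beyond the scatter from that of compound 3.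

Compound 4 `COc1cc(/C=N/N(C)c2nc3ccccc3s2)ccc1O` has not yet been measured. It differs from compound 3 by methyl in place of hydrogen on a nitrogen on an aromatic ring. For the measured compounds named here, the one measured step that bears on this change is the same change made on compound 1: a number 55 percentage points higher from compound 1 to compound 2 (beyond the scatter). That step was large and beyond the scatter. Nothing measured argues that the same change on compound 3 should behave differently, so a large upward step is expected in this assay.

Compound 4 is therefore estimated at 108%, with a range from 80% to 135%. This estimate corresponds to an expected step of a number 47 percentage points higher from compound 3 to compound 4 (beyond the scatter), close in size to the step seen between compound 1 and compound 2.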

Compound 4, a percentage reported as activity, at one concentration (the size of the read-out at that concentration, not a potency) in the Mus musculus assay: 96%
Compound 4: the middle estimate sits 12 percentage points above what was measured, within the range that was stated.
By their numbers in the Mus musculus assay, from the lowest: compounds 1 and 3 (each within the scatter of the next); then compound 4; then compound 2.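

In the Mus musculus assay, methyl in place of hydrogen on a nitrogen on an aromatic ring again raises the number, a number 35 percentage points higher from compound 3 to compound 4 (beyond the scatter), so the direction holds on a second core while the size of the step does not: the same change on two cores in the Mus musculus assay, a number 55 percentage points higher (beyond the scatter) from compound 1 to compound 2 and a number 35 percentage points higher (beyond the scatter) from compound 3 to compound 4, 20 percentage points apart, beyond the scatter of two such steps. Also in the Mus musculus assay, hydrogen in place of methoxy on an aromatic carbon now gives a step beyond the scatter, a number 14 percentage points lower from compound 2 to compound 4 (beyond the scatter), so the outcome of that change depends on what the nitrogen carries: the same change on two cores in the Mus musculus assay, a number 6 percentage points higher (within the scatter) from compound 1 to compound 3 and a number 14 percentage points lower (beyond the scatter) from compound 2 to compound 4, 20 percentage points apart, beyond the scatter of two such steps. In a physicochemical assay on cells (Homo sapiens), with a stated time of 18 h, tested at 1 uM (a higher number here means a weaker effect of the compound at the concentration tested, a lower number a stronger effect), compound 3 gives 65% and compound 4 gives 20% so the methyl change also goes with a stronger effect: the measured a percentage reported as activity, at one concentration (the size of the read-out at that concentration, not a potency) of compound 3, 65%, and of compound 4, 20%, a number 45 percentage points lower (beyond the scatter).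

The compounds shown leave open whether an ethyl group or a longer chain on that nitrogen would behave as methyl does. They also leave open whether the step in the Homo sapiens assay would recur on the core of compound 1.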